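Trifluoromethoxy in Place of Trifluoromethyl: an Expectation

The source may hold more compounds than are shown below. What is called first, only, known or untested is meant among the compounds shown, and "the series" means these compounds.

Compound 1 `Cc1cc(NC(=O)Nc2ccc([N+](=O)[O-])c(C(F)(F)F)c2)c2ccccc2n1` in an ADME assay on Raji cells (Homo sapiens) for cytotoxicity, with a stated time of 72 h (on this read-out lower numbers stand for an effect already at smaller amounts and higher numbers for an effect only at larger amounts of compound), gives > 25000 nM, a limit of the assay.
Compound 2 `Cc1cc(NC(=O)Nc2cccc(C(F)(F)F)c2)c2ccccc2n1` in this assay gives 10000 nM.
Compound 3 `Cc1cc(NC(=O)Nc2ccccc2OC(F)(F)F)c2ccccc2n1` in this assay gives > 25000 nM, again a limit.

For the measured compounds named here, compound 2 thus stands as the only compound with a number in this assay; the two other values are limits. Going by the values given here, the one measured step, an at least 2.5-fold lower number from compound 1 to compound 2 (0.39 log units; beyond the scatter), shows that removing the nitro group moved the value from a limit to a number, and the limit of > 25000 nM in this assay, at which 2 of the 3 values shown sit, shows how little of the range above that limit is resolved.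

Compound 4 `Cc1cc(NC(=O)Nc2cccc(OC(F)(F)F)c2)c2ccccc2n1` differs from compound 2 by trifluoromethoxy in place of trifluoromethyl on an aromatic carbon. Among the compounds with values here, no measured step covers this exchange; compound 3 also carries a trifluoromethoxy group, but its value is a limit and no step to compound 2 is given. In this assay compound 4 is therefore expected to sit close to compound 2, with no step beyond the scatter, though a drift towards the limit would not surprise, so the expected step is a 1.4-fold higher number from compound 2 to compound 4 (0.15 log units; within the scatter). Compound 4 is estimated at 14000 nM, within 5000 nM to 40000 nM.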

Compound 4, half-maximal effective concentration: 9000 nM
For compound 4 the middle estimate is 1.6-fold (0.19 log units) above the measured one, within the range that was stated.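

The exchange, on an aromatic carbon meta to a large group, gives a 1.1-fold lower number from compound 2 to compound 4 (0.05 log units; within the scatter) in this assay. The earlier compounds shown here held no step for this change, and compound 4 now shows that at this place trifluoromethoxy, with its added oxygen and hydrogen-bond acceptor, keeps the read-out a number and level with trifluoromethyl. Two compounds now carry numbers, yet the read-out remains thinly resolved at its upper end: the limit of > 25000 nM in this assay, at which 2 of the 4 values shown sit.

As far as these compounds go, whether a group of another kind at this place, such as an amine or a carboxylic acid, would stay level with these two or reach the limit remains open. From the compounds shown here alone, compound 3 also carries trifluoromethoxy and gives > 25000 nM, a limit, and what moving this group around the ring does remains open too.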